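From pyrimidin-5-yl to 5-cyanopyridin-3-yl on compound 3

The source may hold more compounds than are shown below. What is called first, only, known or untested is meant among the compounds shown, and "the series" means these compounds.

Measured so far in an ADME assay on a cell-free system (plasma, Homo sapiens) (on this read-out lower numbers stand for a smaller free fraction and higher numbers for a larger free fraction), are three compounds:
Compound 1 `CCNC(=O)Nc1nc2cc(-c3cccnc3)c(=O)n(CC3CCOCC3)c2s1` gives 0.14
Compound 2 `CCNC(=O)Nc1nc2cc(-c3cccnc3)c(=O)n(C(C)C(=O)O)c2s1` gives 0.22
Compound 3 `CCNC(=O)Nc1nc2cc(-c3cncnc3)c(=O)n(C(C)C)c2s1` gives 0.15

All three values lie within the usual scatter of each other, so compound 3 cannot be ranked against compound 1 or compound 2. Compound 4 `CCNC(=O)Nc1nc2cc(-c3cncc(C#N)c3)c(=O)n(C(C)C)c2s1` is not yet measured and carries 5-cyanopyridin-3-yl in place of pyrimidin-5-yl on an aromatic carbon as its only difference. For the measured compounds named here, the one measured step of a 1.6-fold higher number from compound 1 to compound 2 (0.20 log units; within the scatter) is within the scatter and concerns a group on an aromatic nitrogen, so no measured step covers this place. No shift in this assay beyond the scatter is therefore expected, and the estimated step of a 1.3-fold lower number from compound 3 to compound 4 (0.10 log units; within the scatter) stays inside it. For compound 4 the expected value is 0.12 with an estimated range from 0.06 to 0.22 around it.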

Compound 4, unbound fraction in the plasma assay: 0.1
The estimate for compound 4 lay 1.2-fold (0.08 log units) above the measured number, within the range that was stated.
By their numbers in the plasma assay, from the lowest: compounds 4, 1, 3 and 2 (each within the scatter of the next, the first and the last beyond it).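

For the compounds shown here, in the plasma assay, 5-cyanopyridin-3-yl in place of pyrimidin-5-yl gives a 1.5-fold lower number from compound 3 to compound 4 (0.18 log units; within the scatter), so this aromatic carbon, which no earlier step covered, shows no shift beyond the scatter with this change. In a physicochemical assay for solubility, in phosphate buffer, at pH 7.4 (on this read-out higher numbers stand for higher solubility and lower numbers for lower solubility), compound 3 gives 7000 nM. In the physicochemical assay compound 4 gives < 5000 nM, which is a limit of the assay and not a number, so the size of this step cannot be read: the limit of < 5000 nM in the physicochemical assay, at which 1 of the 2 values shown sits.

The compounds shown leave open whether an amine or a carboxylic acid at this aromatic carbon would move the free fraction beyond the scatter. They also leave open whether this change reads the same with (oxan-4-yl)methyl or 1-carboxyethyl on the aromatic nitrogen.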